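Benzyl on the Indole Nitrogen: Two Parallel Steps

The source may report more compounds than this note shows. Statements on the series, on what has been measured and on what is new or still open speak of the compounds shown alone.

Compound 1 `CN(C)Cc1ccc2nc(NC(=O)N/N=C/c3c[nH]c4ccccc34)sc2c1` gives 1190 nM in a functional assay on MDA-MB-231 cells (Homo sapiens) for cytotoxicity, read by MTT assay, with a stated time of 72 h; a higher number here means a weaker inhibitor, a lower number a stronger inhibitor. Compound 2 `CN(C)Cc1ccc2nc(NC(=O)N/N=C/c3cn(Cc4ccccc4)c4ccccc34)sc2c1` carries the change benzyl in place of hydrogen on an aromatic nitrogen and gives 1340 nM, so that a 1.1-fold higher number from compound 1 to compound 2 (0.05 log units; within the scatter). Compound 3 `CCN(CC)Cc1ccc2nc(NC(=O)N/N=C/c3c[nH]c4ccccc34)sc2c1` differs from compound 1 by diethylamino in place of dimethylamino on a saturated chain carbon bound to an aromatic carbon. Compound 3 gives 1900 nM; here a 1.6-fold higher number from compound 1 to compound 3 (0.20 log units; within the scatter). Compound 4 `CCN(CC)Cc1ccc2nc(NC(=O)N/N=C/c3cn(Cc4ccccc4)c4ccccc34)sc2c1` has not been measured in this assay. It differs from compound 3 by benzyl in place of hydrogen on an aromatic nitrogen, the same change, at the same place, that separates compound 2 from compound 1. Because a 1.1-fold higher number from compound 1 to compound 2 (0.05 log units; within the scatter) stayed within the scatter, the expected step is a 1.1-fold higher number from compound 3 to compound 4 (0.04 log units; within the scatter), a step of the same kind and size as the earlier one. Compound 4 is therefore estimated at 2100 nM, expected between 1000 nM and 4500 nM.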

Compound 4, half-maximal inhibitory concentration: 1470 nM
The estimate for compound 4 lay 1.4-fold (0.15 log units) above the measured number; the measured number falls inside the stated range.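

Benzyl in place of hydrogen on the aromatic nitrogen gives a 1.3-fold lower number from compound 3 to compound 4 (0.11 log units; within the scatter), and this step agrees with the earlier one within the scatter: the same change on two cores in this assay, a 1.1-fold higher number (0.05 log units; within the scatter) from compound 1 to compound 2 and a 1.3-fold lower number (0.11 log units; within the scatter) from compound 3 to compound 4, 1.5-fold (0.16 log units) apart, within the scatter of two such steps

Diethylamino in place of dimethylamino gives a 1.1-fold higher number from compound 2 to compound 4 (0.04 log units; within the scatter), and it too carries over within the scatter: the same change on two cores in this assay, a 1.6-fold higher number (0.20 log units; within the scatter) from compound 1 to compound 3 and a 1.1-fold higher number (0.04 log units; within the scatter) from compound 2 to compound 4, 1.5-fold (0.16 log units) apart, within the scatter of two such steps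

This shows that, in these four compounds, neither change moves the number beyond the scatter on either core; it does not show that either change has a real effect, or that the agreement would hold on any other core.

The compounds shown leave open whether a carboxylic acid on the benzyl ring, a longer chain on the aromatic nitrogen, or morpholine in place of diethylamino would move the number beyond the scatter.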